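Methoxy scan on a dihydropyranone and lactone pair

This account rests on a few compounds, and the source may have more. Where it says the series, first, only, none or still open, it means among the compounds named here.

Measured so far:
Compound 1, `COc1ccc(/C=C/C2CC(=O)C=CO2)cc1OC`, 86.9 uM
Compound 2, `COc1cc(/C=C/C2CC(=O)C=CO2)cc(OC)c1OC`, 102 uM
Compound 3, `COc1ccc(/C=C/C2CC=CC(=O)O2)cc1OC`, 23.9 uM

In a functional assay on U-251 cells (Homo sapiens) for inhibition, read by sulforhodamine B assay, with a stated time of 48 h (a lower number here means a stronger inhibitor of growth, a higher number a weaker inhibitor of growth), compound 3 gives the lowest number of the three. The difference between the core of compound 3 and the core of compound 1 is not broken down here. Within the first core, the change from compound 1 to compound 2, (methoxy in place of hydrogen on an aromatic carbon), gives a 1.2-fold higher number from compound 1 to compound 2 (0.07 log units; within the scatter).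

Compound 4, `COc1cc(OC)c(OC)cc1/C=C/C1CC=CC(=O)O1`, is not yet measured. It arises from compound 3 by methoxy in place of hydrogen on an aromatic carbon, the same kind of change as that from compound 1 to compound 2, though the surroundings differ: here the entering group stands ortho to a group of 9 heavy atoms and para to a methoxy group, whereas before it stood ortho to a methoxy group and meta to that larger group. Because a 1.2-fold higher number from compound 1 to compound 2 (0.07 log units; within the scatter) lies within the scatter, the step from compound 3 to compound 4 is expected to be similar, a 1.2-fold higher number from compound 3 to compound 4 (0.07 log units; within the scatter). Compound 4 is therefore estimated at 28 uM, with a range from 12 uM to 70 uM.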

Compound 4, concentration for growth inhibition (reported as GI): 11.5 uM
Estimate against measurement, compound 4: 2.4-fold (0.39 log units) above; measured number outside the range, below it.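

In this assay methoxy in place of hydrogen on an aromatic carbon gives a 2.1-fold lower number from compound 3 to compound 4 (0.32 log units; beyond the scatter) on the core of compound 3, against a 1.2-fold higher number from compound 1 to compound 2 (0.07 log units; within the scatter) on the core of compound 1. The two steps cannot be told apart: the same change on two cores in this assay, a 1.2-fold higher number (0.07 log units; within the scatter) from compound 1 to compound 2 and a 2.1-fold lower number (0.32 log units; beyond the scatter) from compound 3 to compound 4, 2.4-fold (0.39 log units) apart, within the scatter of two such steps. Going by these compounds alone, this does not show that the change carries over unchanged, as each core gives only one pair and the entering methoxy stands in a different place in each, in compound 4 ortho to a group of 9 heavy atoms and para to a methoxy group.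

Open, as far as these compounds go, is whether the methoxy pattern of compound 2 on the core of compound 3 gives the same step, which would separate place from core. Also open, from the compounds shown here alone, is how a hydroxy group or an amine at that carbon compares with methoxy on either core.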